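The source may hold more compounds than are shown below. What is called first, only, known or untested is meant among the compounds shown, and "the series" means these compounds.

Measured compounds:
- compound 1 `COC(=O)/C=C/c1cccc(N(Cc2ccc(/C=C/c3ccccc3F)cc2)C(=O)C2CCCCC2)c1` — 64 nM
- compound 2 `COC(=O)/C=C/c1cccc(N(Cc2ccc(/C=C/c3cccc(F)c3)cc2)C(=O)C2CCCCC2)c1` — 86 nM
- compound 3 `COC(=O)/C=C/c1cccc(N(Cc2ccc(/C=C/c3cccc(F)c3)cc2)C(=O)C(C)C)c1` — 71 nM

All three were tested in an assay on isolated protein with Bile acid receptor (Homo sapiens) as the target; on this read-out lower numbers stand for an effect already at smaller amounts and higher numbers for an effect only at larger amounts of compound. Compound 2 has the highest of the three numbers, but the gaps around it are small: a 1.3-fold higher number from compound 1 to compound 2 (0.13 log units; within the scatter) and a 1.2-fold lower number from compound 2 to compound 3 (0.08 log units; within the scatter) both lie within the scatter of this assay, so the three compounds cannot be told apart on these numbers.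

Compound 4 `COC(=O)/C=C/c1cccc(N(Cc2ccc(/C=C/c3scnc3C)cc2)C(=O)C2CCCCC2)c1` has not yet been measured in this assay. It differs from compound 2 in one place: 4-methyl-1,3-thiazol-5-yl in place of 3-fluorophenyl on a double-bonded chain carbon bound to a double-bonded chain carbon. Neither of the measured steps touches this part of the molecule in the same way. The step from compound 1 to compound 2 moves a fluorine atom within the same kind of ring, and the step from compound 2 to compound 3 changes the group on the carbonyl carbon; both stayed within the scatter. Within the data shown here, there is thus no measured precedent for exchanging this ring for a five-membered ring with two hetero atoms, and the expectation rests on the observation that the changes seen so far moved this assay little.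

Compound 4 is therefore expected to give about 100 nM, with a range from 35 nM to 300 nM, an expected step of a 1.2-fold higher number from compound 2 to compound 4 (0.07 log units; within the scatter), that is, none clearly beyond the scatter, though with wide uncertainty.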

Compound 4, half-maximal effective concentration: 227 nM
Compound 4: the middle estimate sits 2.3-fold (0.36 log units) below what was measured; the measured number falls inside the stated range.
By their numbers in this assay, from the lowest: compounds 1, 3 and 2 (each within the scatter of the next); then compound 4.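

In this assay, among these compounds, the ring on the double-bonded chain carbon is the one place so far where a change moves the number beyond the scatter: 4-methyl-1,3-thiazol-5-yl in place of 3-fluorophenyl gives a 2.6-fold higher number from compound 2 to compound 4 (0.42 log units; beyond the scatter), and in place of 2-fluorophenyl it gives a 3.5-fold higher number from compound 1 to compound 4 (0.55 log units; beyond the scatter). Both steps are modest, but together with the step between the two fluorophenyl compounds, which stayed within the scatter, they show that this position responds more to exchanging the whole ring than to moving the fluorine on it. The new ring differs from the fluorophenyl rings in its size, its hetero atoms, its methyl group and its hydrogen-bond acceptors, and no available data explain which of these differences accounts for the higher number.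

Open, as far as these compounds go, is whether the higher number belongs to the five-membered ring or to its methyl group, which a plain 1,3-thiazol-5-yl would separate, and whether a pyridin-3-yl ring would fall with the fluorophenyl compounds or with compound 4. Also open, from the compounds shown here alone, is whether the same exchange gives a step of similar size with isopropyl in place of cyclohexyl on the carbonyl carbon, as in compound 3.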